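Swapping bromo for methylsulfanyl on the aryl tail

The source may hold more compounds than are shown below. What is called first, only, known or untested is meant among the compounds shown, and "the series" means these compounds.

Measured compounds:
compound 1 `CSc1cccc(CCCCCC(=O)N2CCOC2=O)c1`: 12800 nM
compound 2 `O=C(CCCCCc1ccc(Br)cc1)N1CCOC1=O`: 8510 nM

In an assay on HEK293 cells for inhibition of N-acylethanolamine-hydrolyzing acid amidase (Rattus norvegicus), read by LC-MS, with a stated time of 30 min (a lower number here means a stronger inhibitor, a higher number a weaker inhibitor), compound 1 gives 12800 nM, and compound 2 gives 8510 nM. Compound 2 carries the smaller of the two numbers, but its distance to compound 1 lies within the scatter, so the two cannot be told apart. Compound 3 `CSc1ccc(CCCCCC(=O)N2CCOC2=O)cc1` differs from compound 2 by methylsulfanyl in place of bromo on an aromatic carbon. Within the data shown here, with no measured step of this kind available, the account expects little movement in this assay, none clearly beyond the scatter. Compound 3 is estimated at 9500 nM, in the range 3000 nM to 30000 nM, which means an expected step of a 1.1-fold higher number from compound 2 to compound 3 (0.05 log units; within the scatter).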

Compound 3, half-maximal inhibitory concentration: > 20000 nM
Compound 3 ended at the assay's limit; the forecaster's own chance of this, stated with the estimate: 10%; middle value at least 2.1-fold (0.32 log units) from the limit.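

Among these compounds, on an aromatic carbon para to a large group, methylsulfanyl in place of bromo is not a neutral swap: it brings an at least 2.3-fold higher number from compound 2 to compound 3 (0.37 log units; beyond the scatter), the first step that can be read at all. For compound 3 the reading in this assay is > 20000 nM, a limit of the assay and not a number: the limit of > 20000 nM in this assay, at which 1 of the 3 values shown sits.

From the compounds shown here alone, the true size of this step therefore stays unknown. Also open, going by these compounds, is whether chloro, methoxy or an amine at this position would keep the number of compound 2, and whether a longer chain would change the picture.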